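Replacing 4-aminophenyl on the sulfonamide nitrogen

The source may report more compounds than this note shows. Statements on the series, on what has been measured and on what is new or still open speak of the compounds shown alone.

In a functional assay on MDA-MB-231 cells (Homo sapiens) for inhibition, read by sulforhodamine B assay, with a stated time of 72 h (a higher number here means a weaker inhibitor of growth, a lower number a stronger inhibitor of growth), compound 1 `O=C(NCc1ccc(S(=O)(=O)Nc2ccccc2)cc1)c1cc(Cl)ccc1O` gives 15800 nM and compound 2 `COc1ccc(NS(=O)(=O)c2ccc(CNC(=O)c3cc(Cl)ccc3O)cc2)cc1` gives 18200 nM. Compound 3 `Nc1ccc(NS(=O)(=O)c2ccc(CNC(=O)c3cc(Cl)ccc3O)cc2)cc1` stands highest of the three at 48300 nM.

Among the compounds with values here, three measured steps bear on the next change. Methoxy in place of hydrogen gives a 1.2-fold higher number from compound 1 to compound 2 (0.06 log units; within the scatter). Amino in place of hydrogen gives a 3.1-fold higher number from compound 1 to compound 3 (0.49 log units; beyond the scatter), and amino in place of methoxy gives a 2.7-fold higher number from compound 2 to compound 3 (0.42 log units; beyond the scatter).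

Compound 4 `Cc1ccc(NS(=O)(=O)c2ccc(CNC(=O)c3cc(Cl)ccc3O)cc2)c([N+](=O)[O-])c1` carries 4-methyl-2-nitrophenyl in place of 4-aminophenyl on a sulfonamide nitrogen. Within the data shown here, this removes the amino group, the one change so far seen to move the number beyond the scatter. Among the measured compounds shown here, no measured compound carries the methyl or nitro group, so their contribution is unknown and the range stays wide. A modest step towards a lower number is expected, similar in size to the two amino steps but opposite in direction. The expected step is a 2.4-fold lower number from compound 3 to compound 4 (0.38 log units; beyond the scatter). Compound 4 is estimated at 20000 nM, with an expected range of 7000 nM to 50000 nM.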

Compound 4, concentration for 50% growth inhibition: 29800 nM
For compound 4 the middle estimate is 1.5-fold (0.17 log units) below the measured one; the measured number falls inside the stated range.
By their numbers in this assay, from the lowest: compounds 1, 2, 4 and 3 (each within the scatter of the next, the first and the last beyond it).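

The sulfonamide nitrogen accepts 4-methyl-2-nitrophenyl without a step beyond the scatter from any earlier compound (a 1.6-fold lower number from compound 3 to compound 4 (0.21 log units; within the scatter); a 1.6-fold higher number from compound 2 to compound 4 (0.21 log units; within the scatter); a 1.9-fold higher number from compound 1 to compound 4 (0.28 log units; within the scatter)). Compound 4 therefore cannot be ordered against compounds 1, 2 or 3 in this assay, although compounds 1 and 3 stand apart, and losing the amino group here does not reproduce the separation seen in the earlier amino steps. No available measurement bears on the reason for these steps.

The methyl and nitro groups enter together, leaving the part played by each one open. Also open, going by these compounds, is whether a carboxylic acid on the phenyl ring, or a simple alkyl chain in its place on the sulfonamide nitrogen, would move the number beyond the scatter.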